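Amine substituent changes in a cytotoxicity series

The source may report more compounds than this note shows. Statements on the series, on what has been measured and on what is new or still open speak of the compounds shown alone.

Compound 1 `C[C@@H](Cn1ccc(-c2ccc(C#N)c(Cl)c2)n1)NS(=O)(=O)c1cn(C)cn1`, compound 2 `Cc1ccnc(N[C@@H](C)Cn2ccc(-c3ccc(C#N)c(Cl)c3)n2)n1` and compound 3 `C[C@@H](Cn1ccc(-c2ccc(C#N)c(Cl)c2)n1)Nc1nccc(Cl)n1` share one core and differ only in the group on the amine nitrogen. In an ADME assay on PC-3 cells (Homo sapiens) for cytotoxicity, read by CCK-8 assay, with a stated time of 6 days (a lower number here means a stronger inhibitor, a higher number a weaker inhibitor), compound 3 gives only a limit, > 30000 nM. Compound 1 likewise gives a limit, > 30000 nM. Compound 2 also gives a limit, > 30000 nM. Because all three sit at the limit of > 30000 nM in this assay, at which 3 of the 3 values shown sit, the steps a step that the two limits leave unreadable from compound 1 to compound 2, a step that the two limits leave unreadable from compound 1 to compound 3 and a step that the two limits leave unreadable from compound 2 to compound 3 cannot be sized. Compound 4 `C[C@@H](Cn1ccc(-c2ccc(C#N)c(Cl)c2)n1)Nc1ncnc2nc[nH]c12` differs from compound 3 by a group of 9 heavy atoms (5 carbon, 4 nitrogen; one five-membered aromatic ring with 2 hetero atoms, one six-membered aromatic ring with 2 hetero atoms) in place of a group of 7 heavy atoms (4 carbon, 2 nitrogen, 1 chlorine; one six-membered aromatic ring with 2 hetero atoms), on an amine nitrogen. For the measured compounds named here, none of the measured steps can be read, so nothing points to a change beyond the scatter in this assay. Compound 4 is therefore expected to remain at a limit, estimated at 30000 nM (range 10000 nM to 60000 nM), an expected step of a number no higher from compound 3 to compound 4 (the limit leaves the size open).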

Compound 4, half-maximal inhibitory concentration: 14100 nM
The estimate for compound 4 lay 2.1-fold (0.33 log units) above the measured number, within the range that was stated.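

In this assay, for the compounds shown here, the amine nitrogen can carry a group that gives a readable number, which the earlier compounds did not show: the limit of > 30000 nM in this assay, at which 3 of the 4 values shown sit. Placing the group with one five-membered and one six-membered aromatic ring on this nitrogen gives an at least 2.1-fold lower number from compound 3 to compound 4 (0.32 log units; beyond the scatter), an at least 2.1-fold lower number from compound 2 to compound 4 (0.32 log units; beyond the scatter) and an at least 2.1-fold lower number from compound 1 to compound 4 (0.32 log units; beyond the scatter). As far as these compounds go, all three steps start from a limit, so their full size stays open.

The compounds shown do not separate the five-membered ring from the rest of this group as the source of the step. From the compounds shown here alone, whether a phenyl or morpholine group on the amine nitrogen also gives a readable number remains open.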